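Fluoro to Bromo: Expecting the Cytotoxicity of Compound 4

The compounds below may be only part of what the source reports. "The series", "measured", "known", "first", "only" and "open" are said of these compounds alone.

Compound 1 `COc1ccccc1/C=c1/[nH]c(=O)/c(=C\c2ccccc2OC)[nH]c1=O`: "not active" (no number reported)
Compound 2 `COc1ccccc1/C=c1\c(=O)[nH]/c(=C/c2cccc(Cl)c2Cl)c(=O)n1C`: 110 nM
Compound 3 `C=CCn1c(=O)/c(=C\c2cccc(F)c2)[nH]c(=O)/c1=C\c1ccccc1OC`: 4100 nM

All three were tested in a functional assay on K562 cells (Homo sapiens) for cytotoxicity, read by CCK-8 assay, with a stated time of 72 h; a higher number here means a weaker inhibitor, a lower number a stronger inhibitor. Compound 3 gives 4100 nM, the higher of the two numbers obtained; compound 2 gives 110 nM. Compound 1 gives "not active" (no number reported), so no number stands for it.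

Compound 4 `C=CCn1c(=O)/c(=C\c2cccc(Br)c2)[nH]c(=O)/c1=C\c1ccccc1OC` differs from compound 3 in one place: bromo in place of fluoro on an aromatic carbon. Among the compounds with values here, no pair of measured compounds isolates a change of this kind, so the expectation rests on compound 3 alone. Bromo in place of fluoro on an aromatic carbon is expected to move the number little, so the step of a 1.4-fold lower number from compound 3 to compound 4 (0.14 log units; within the scatter) is expected to stay within the scatter. Compound 4 is therefore estimated at 3000 nM, with a range from 1000 nM to 9000 nM.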

Compound 4, half-maximal inhibitory concentration: 2400 nM
Beside the measured number, compound 4's estimate is 1.3-fold (0.10 log units) above it; low and high end bracket the measured number.
By their numbers in this assay, from the lowest: compound 2; then compounds 4 and 3 (each within the scatter of the next).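

In this assay, putting bromo in place of fluoro on the aromatic carbon gives a 1.7-fold lower number from compound 3 to compound 4 (0.23 log units; within the scatter). This is the only step shown that isolates a single change, and it means that at this place, meta to a large group, the two compounds cannot be told apart. No separate measurement bears on this result. As far as these compounds go, whether an amine or a carboxylic acid on this same carbon would also stay within the scatter remains open. So does whether the change from fluoro to bromo would give the same result on a different parent compound.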